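The compounds below may be only part of what the source reports. "The series", "measured", "known", "first", "only" and "open" are said of these compounds alone.

Measured compounds:
compound 1 `c1ccc(C2CCCCN2C2CCN(CCCc3c[nH]c4ccc(-n5cnnc5)cc34)CC2)cc1`, in an assay on CHO cells for agonist activity at 5-hydroxytryptamine receptor 1D (Homo sapiens), read by GTPgammaS binding (a lower number here means that less compound is needed, a higher number that more compound is needed for the effect), compound 1 gives 4.7 nM;
compound 2 `NC(=O)OC[C@H](NC1CCN(CCCc2c[nH]c3ccc(-n4cnnc4)cc23)CC1)c1ccccc1`, compound 2 gives 9.3 nM;
compound 3 `OC[C@H](NC1CCN(CCCc2c[nH]c3ccc(-n4ccnc4)cc23)CC1)c1ccccc1`, compound 3 gives 0.8 nM.

Among the three numbers, compound 2 has the highest. Its nearest neighbour is compound 1, whose number is lower but within the scatter, so no order between compound 2 and compound 1 can be read. Among the compounds with values here, compound 3 stands furthest away, with a number lower than that of compound 2 by a gap beyond the scatter; compound 3 is thus the one compound here that clearly needs less material.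

Compound 4 `CC(CO)(NC1CCN(CCCc2c[nH]c3ccc(-n4cnnc4)cc23)CC1)c1ccccc1` is not yet measured. It differs from compound 2 only at the amine nitrogen: 1-(hydroxymethyl)-1-phenylethyl in place of 2-(carbamoyloxy)-1-phenylethyl on an amine nitrogen. Within the data shown here, the shared core of compound 2 is kept unchanged, and compound 3 differs in its core, so no measured pair isolates this change.

Among the measured compounds shown here, what compound 3 shows, with its hydroxymethyl group, is the only guide. A step downward from compound 2 is expected for compound 4, of moderate size, because compound 3 gives 0.8 nM with a related hydroxymethyl side chain; the expected step is a 2.7-fold lower number from compound 2 to compound 4 (0.42 log units; beyond the scatter). The estimate for compound 4 in this assay is 3.5 nM, with a range from 1 nM to 12 nM.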

Compound 4, half-maximal effective concentration: 3.4 nM
Beside the measured number, compound 4's estimate is 1.0-fold (0.01 log units) above it; low and high end bracket the measured number.
By their numbers in this assay, from the lowest: compound 3; then compounds 4, 1 and 2 (each within the scatter of the next, the first and the last beyond it).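

In this assay, the substituent on the amine nitrogen now has its first readable step: 1-(hydroxymethyl)-1-phenylethyl in place of 2-(carbamoyloxy)-1-phenylethyl gives a 2.7-fold lower number from compound 2 to compound 4 (0.44 log units; beyond the scatter). On the shared core of compound 2, the effect therefore does not depend on the carbamoyloxy group, and the position accepts a substituent with a free hydroxyl and no defined stereocentre, although the exchange alters the carbamoyloxy end and the substitution of the carbon on the amine nitrogen in one step, so the size of the step cannot be divided between them. No measurement of any property of these compounds bears on the step, and it stands without an explanation.

The compounds shown leave open whether the hydroxyl itself matters at this position, which a methoxymethyl, aminomethyl or carboxylic acid group in its place on the same 1-phenylethyl frame would address. They also leave open how the unbranched 2-hydroxy-1-phenylethyl chain of compound 3 behaves on the shared core of compound 2, as compound 3 differs from compound 2 and compound 4 in its core too and offers no clean comparison.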